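Unsaturating the Amide Chain of a Naphthalene Carbinol

A few compounds are considered here, and "the series" means these few. Any claim that something is new, unique, unknown or untested is made for them only; others in the source may bear on it.

Measured compounds:
Compound 1, `CC(C)C(=O)Nc1c(C(O)(C(F)(F)F)C(F)(F)F)ccc2ccccc12`, gives 6630 nM in an assay on LtK cells with ATP-sensitive inward rectifier potassium channel 11 (Homo sapiens) as the target; a lower number here means that less compound is needed, a higher number that more compound is needed for the effect.
Compound 2, `CCCC(=O)Nc1c(C(O)(C(F)(F)F)C(F)(F)F)ccc2ccccc12`, gives 131 nM in this assay.

For the measured compounds named here, compound 2 stands lowest of the two numbers measured so far. Going by the values given here, its only neighbour is compound 1, and the single step connecting them, a 51-fold lower number from compound 1 to compound 2 (1.70 log units; beyond the scatter), is large and well beyond the usual scatter. Compound 3, `C/C=C/C(=O)Nc1c(C(O)(C(F)(F)F)C(F)(F)F)ccc2ccccc12`, has not yet been measured. Among the compounds with values here, it differs from compound 2 in one place: prop-1-en-1-yl in place of propyl on a carbonyl carbon The one measured step that bears on this change, a 51-fold lower number from compound 1 to compound 2 (1.70 log units; beyond the scatter), replaced a branched chain with a straight one on the same carbonyl carbon. Prop-1-en-1-yl, like propyl, is not a branched group, so the change from compound 2 to compound 3 does not repeat that earlier swap; it only adds a double bond outside aromatic rings. Within the data shown here, no measured step speaks to such an addition. The expectation is therefore a step of a 1.1-fold higher number from compound 2 to compound 3 (0.06 log units; within the scatter) in this assay, small enough to stay within the scatter in either direction. Compound 3 is expected to give about 150 nM, with a range from 40 nM to 600 nM.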

Compound 3, half-maximal effective concentration: 72 nM
Beside the measured number, compound 3's estimate is 2.1-fold (0.32 log units) above it; the measured number falls inside the stated range.
By their numbers in this assay, from the lowest: compounds 3 and 2 (each within the scatter of the next); then compound 1.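

In this assay, putting a double bond into the straight chain on the carbonyl carbon gives a 1.8-fold lower number from compound 2 to compound 3 (0.26 log units; within the scatter), so as far as these numbers can tell, this position accepts prop-1-en-1-yl as well as it accepts propyl. Set against the branched chain, the new group gives a 92-fold lower number from compound 1 to compound 3 (1.96 log units; beyond the scatter) and thus shows for a second straight chain what propyl showed first: among the three compounds, both unbranched chains give far lower numbers than isopropyl, and none goes against this. No measurement available here bears on the reason for either step.

From the compounds shown here alone, it remains open whether a longer chain such as butyl, or a chain with a triple bond such as prop-1-yn-1-yl, would stay close to the numbers of compound 2 and compound 3. Also open, going by these compounds, is how the other geometric form of the double bond, or a small ring such as cyclopropyl on the same carbonyl carbon, would read in this assay, and whether such a ring would behave more like the straight chains or like isopropyl.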